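A few compounds are considered here, and "the series" means these few. Any claim that something is new, unique, unknown or untested is made for them only; others in the source may bear on it.

Compound 1 `CC(O)(C(=O)Nc1ccc(S(=O)(=O)c2cccc(O)c2)cc1)C(F)(F)F` gave 18000 nM in a functional assay (Cavia porcellus) with sulfonylurea receptors; K-ATP channels (Homo sapiens) as the target; on this read-out higher numbers stand for weaker inhibition and lower numbers for stronger inhibition.
Compound 2 `COc1ccc(S(=O)(=O)c2ccc(NC(=O)C(C)(O)C(F)(F)F)cc2)cc1` gave only the limit > 30000 nM in this assay.

In this assay compound 2 thus stands at a limit and not at a number; that limit is the limit of > 30000 nM in this assay, at which 1 of the 2 values shown sits. Compound 3 `Cc1ccc(S(=O)(=O)c2ccc(NC(=O)C(C)(O)C(F)(F)F)cc2)cc1` differs from compound 2 by methyl in place of methoxy on an aromatic carbon. For the measured compounds named here, only one measured step touches this position: an at least 1.6-fold higher number from compound 1 to compound 2 (0.22 log units; that floor lies within the scatter), which exchanged a different group, so it says little about swapping methoxy for methyl. Compound 3 is therefore expected to stay near the limit, with no step beyond the scatter: a number no higher from compound 2 to compound 3 (the limit leaves the size open). Compound 3 is estimated at 30000 nM, between 12000 nM and 80000 nM.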

Compound 3, half-maximal inhibitory concentration: > 30000 nM
Compound 3 ended at the assay's limit (the forecaster's own chance of this, stated with the estimate: 65%); the middle value lies on the limit itself.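

Compound 3, with methyl in place of the methoxy of compound 2, also gives only a limit in this assay, so the step between these two compounds cannot be read. Against the 3-hydroxyphenyl of compound 1, 4-methylphenyl gives an at least 1.6-fold higher number from compound 1 to compound 3 (0.22 log units; that floor lies within the scatter), so no difference beyond the scatter is established. Neither methoxy nor methyl at this position gives a measurable number in this read-out: the limit of > 30000 nM in this assay, at which 2 of the 3 values shown sit.

From the compounds shown here alone, whether an amine or a carboxylic acid in place of the methyl would bring a number under that limit stays open. So does how compound 2 and compound 3 truly compare.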